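Bromine to Fluorine: One Change on a Shared Core

The source may hold more compounds than are shown below. What is called first, only, known or untested is meant among the compounds shown, and "the series" means these compounds.

Compound 1, `Brc1ccccc1OCC1=NCCO1`: 40%
Compound 2, `O=[N+]([O-])c1ccc(OCC2=NCCO2)cc1`: 20%

Of the compounds shown here, two have been tested in a toxicity assay on the whole organism with Rattus norvegicus as the target, at a dose of 400 mg/kg by the oral route; a higher number here means a stronger effect of the compound at the dose given, a lower number a weaker effect. Compound 1 gives 40%, the higher of the two numbers, while compound 2 gives 20%, a gap beyond the usual scatter. Compound 3, `Fc1ccccc1OCC1=NCCO1`, has not yet been measured; it differs from compound 1 by fluoro in place of bromo on an aromatic carbon. For the measured compounds named here, no measured pair shows this swap, so its effect in this assay is unknown. A small downward step, or none beyond the scatter, is expected: a number 10 percentage points lower from compound 1 to compound 3 (within the scatter). Compound 3 is therefore estimated at 30%, with a likely range from 10% to 55%.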

Compound 3, a percentage reported as activity, at one dose (the size of the read-out at that dose, not a potency): 20%
The estimate for compound 3 lay 10 percentage points above the measured number; the range from low to high includes it.
By their numbers in this assay, from the lowest: compounds 2 and 3 (each within the scatter of the next); then compound 1.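

Within this assay the exchange of bromo for fluoro gives a number 20 percentage points lower from compound 1 to compound 3 (beyond the scatter) and so shows that the halogen at this place on the ring matters: changing this one atom moves the read-out by more than the scatter. Nothing available explains the drop. Still open, going by these compounds, is how a chloro or a methyl group at the same place would compare with bromo and fluoro. So is whether an amine or a carboxylic acid there would keep any of the effect.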